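Trimethoxyphenyl oxadiazolines: the pendant aryl and BGC-823 inhibition

A few compounds are considered here, and "the series" means these few. Any claim that something is new, unique, unknown or untested is made for them only; others in the source may bear on it.

Compound 1 `COc1cc(C2=NN(C(C)=O)C(c3c(Cl)cccc3Cl)O2)cc(OC)c1OC` and compound 2 `COc1cc(C2=NN(C(C)=O)C(c3cc(Cl)cc(Cl)c3)O2)cc(OC)c1OC` share one core and differ only in the pendant aryl. In a functional assay on BGC-823 cells (Homo sapiens) for antiproliferative activity, read by MTT assay, tested at 1 uM (on this read-out higher numbers stand for a stronger effect at the one concentration tested and lower numbers for a weaker effect), compound 1 gives -1.4% and compound 2 gives 0%; the change a number 1.4 percentage points higher from compound 1 to compound 2 (within the scatter) is within the scatter, so compound 2 stands level with compound 1 and neither can be called stronger. Compound 3 `COc1ccc(C2OC(c3cc(OC)c(OC)c(OC)c3)=NN2C(C)=O)c(OC)c1` carries 2,4-dimethoxyphenyl in place of 3,5-dichlorophenyl on a saturated ring carbon. Going by the values given here, no measured step exchanges a dichloro pattern for methoxy groups, so the only guide is that both aryl variants sit near zero; no step beyond the scatter is expected, giving an expected a number 3 percentage points higher from compound 2 to compound 3 (within the scatter). Compound 3 is estimated at 3%, range -10% to 20%.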

Compound 3, a percentage reported as inhibition, at one concentration (the size of the read-out at that concentration, not a potency): 6.3%
For compound 3 the middle estimate is 3.3 percentage points below the measured one, and the stated range covers the measured number.
By their numbers in this assay, from the lowest: compounds 1, 2 and 3 (each within the scatter of the next).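

In this assay the 2,4-dimethoxyphenyl group on the saturated ring carbon gives a number 6.3 percentage points higher from compound 2 to compound 3 (within the scatter) and a number 7.7 percentage points higher from compound 1 to compound 3 (within the scatter) against the two dichlorophenyl groups. Going by these compounds alone, at this position, methoxy groups with their hydrogen-bond acceptors in place of chlorine therefore separate no compound from the others, so the three aryl variants cannot be ranked. No evidence at hand bears on this result.

Open, on these data alone, is whether an amine or a carboxylic acid on the pendant aryl, or a longer chain in its place, would give a step beyond the scatter.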